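This account rests on a few compounds, and the source may have more. Where it says the series, first, only, none or still open, it means among the compounds named here.

Compound 1 `Clc1ccc(-c2cc(-c3ccccc3)n[nH]2)cc1` is the stronger of the two measured entries in an assay on mitochondria from brain for inhibition of Amine oxidase [flavin-containing] B (Bos taurus), read by fluorescence (on this read-out lower numbers stand for stronger inhibition and higher numbers for weaker inhibition), where compound 1 gives 6.03 nM. Among the compounds with values here, its only measured neighbour, compound 2 `Fc1ccc(-c2cc(-c3ccccc3)n[nH]2)cc1`, gives 30.2 nM in this assay, and the step of a 5.0-fold higher number from compound 1 to compound 2 (0.70 log units; beyond the scatter) came with the change from chloro to fluoro. Compound 3 `Clc1ccc(-c2cc(-c3ccc(Cl)cc3)[nH]n2)cc1` differs from compound 1 by chloro in place of hydrogen on an aromatic carbon. Within the data shown here, no measured step addresses a second chloro on the other ring; the halogen swap only shows that the existing chloro matters. Compound 3 is therefore expected to stay close to compound 1, a step of a 1.2-fold lower number from compound 1 to compound 3 (0.08 log units; within the scatter) in this assay, giving an estimate of 5 nM within 1.5 nM to 15 nM.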

Compound 3, half-maximal inhibitory concentration: 6030 nM
For compound 3 the middle estimate is 1200-fold (3.08 log units) below the measured one; the whole stated range lies below it.
By their numbers in this assay, from the lowest: compound 1; then compound 2; then compound 3.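

In this assay, chloro in place of hydrogen on the unsubstituted six-membered aromatic ring gives a 1000-fold higher number from compound 1 to compound 3 (3.00 log units; beyond the scatter), a large loss. Within the data shown here, the earlier pair varied only the halogen already present, so this is the first reading showing that this position, para to a large group, is highly sensitive to substitution. Nothing available explains the loss. Still open, as far as these compounds go, is whether the loss is particular to chloro or also follows with fluoro, methoxy or an amine at this position.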